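A limit, and a much larger side chain

The source may report more compounds than this note shows. Statements on the series, on what has been measured and on what is new or still open speak of the compounds shown alone.

Values in an ADME assay on Vero cells (Chlorocebus sabaeus) for cytotoxicity; on this read-out higher numbers stand for lower toxicity in this test and lower numbers for higher toxicity in this test:
- compound 1 `COc1ccccc1-c1nn2cnnc2s1` gives > 80000 nM
- compound 2 `CCOc1ccccc1-c1nn2cnnc2s1` gives > 65000 nM
- compound 3 `c1ccc(-c2nn3cnnc3s2)c(OCCC2CCOCC2)c1` is not yet measured

In this assay compound 2 stands at > 65000 nM as a limit, not a number. The value for compound 1 is a limit too. Compound 3 follows from compound 2 through one change: oxan-4-yl in place of hydrogen on a saturated chain carbon, two bonds along the chain from an oxygen on an aromatic ring and nothing else. Among the measured compounds shown here, the only measured step that bears on it is a step that the two limits leave unreadable from compound 1 to compound 2 and it gives no size to build on. A modest step towards lower numbers is therefore expected, with little confidence. The expected step is an at least 1.6-fold lower number from compound 2 to compound 3 (0.21 log units; that floor lies within the scatter) as an estimate only. Compound 3 is estimated at 40000 nM with 12000 nM to 100000 nM as the expected range.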

Compound 3, half-maximal cytotoxic concentration: > 50000 nM
Compound 3: only a limit was reported (the forecaster's own chance of this, stated with the estimate: 55%); at least 1.2-fold (0.09 log units) between middle value and limit.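

Among the compounds shown here, compound 1, compound 2 and compound 3 all stand as limits in this assay, and no step among them can be read. The compounds shown leave open whether oxan-4-yl in that place changes this read-out at all.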